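A Side Chain Change in a Cytotoxicity Series

The compounds below may be only part of what the source reports. "The series", "measured", "known", "first", "only" and "open" are said of these compounds alone.

compound 1 `CC(C)=CCC/C(C)=C\CC/C(C)=C\Cc1cc[nH]c1` gives 13700 nM
compound 2 `CC(C)=CCC/C(C)=C/CC[C@](C)(O)[C@H](O)Cc1c[nH]c([N+](=O)[O-])c1` gives 31100 nM
compound 3 `CC(C)=CCC/C(C)=C/CC[C@@](C)(Cl)[C@H](O)Cc1c[nH]c([N+](=O)[O-])c1` gives "not active" (no number reported)

In a functional assay on HCT-116 cells (Homo sapiens) for cytotoxicity (on this read-out higher numbers stand for weaker inhibition and lower numbers for stronger inhibition), compound 3 is reported as "not active" (no number reported) without a number, so it has no place on the numeric scale that compound 1 and compound 2 provide. Going by the values given here, the one structural change that leads to compound 4 `C/C(=C\CC[C@@](C)(Cl)[C@H](O)Cc1c[nH]c([N+](=O)[O-])c1)CC[C@@H](O)C(C)(C)O` is 1,2-dihydroxy-2-methylpropyl in place of 2-methylprop-1-en-1-yl on a saturated chain carbon, two bonds along the chain from a double-bonded chain carbon and the rest of the structure stays the same. Among the compounds with values here, no measured pair in this small set shows the same change, and compound 3 offers no number to start from, so any step can only be judged loosely. The expectation is of no clear gain in inhibition, with compound 4 either reported without a number or giving a value in the region of compound 2 at 31100 nM in the same read-out. Compound 4 is estimated at 30000 nM if a number is reported at all, with an expected range from 10000 nM to 80000 nM in this assay for now.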

Compound 4, half-maximal inhibitory concentration: "not active" (no number reported)
Compound 4: no number reported; the estimate stays without a comparison.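

In this assay compound 3 gives "not active" (no number reported) and compound 4 gives "not active" (no number reported), so no step can be read between them, and no evidence bears on this result. The compounds shown leave open whether exchanging 2-methylprop-1-en-1-yl for 1,2-dihydroxy-2-methylpropyl changes inhibition at all.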